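The source may hold more compounds than are shown below. What is called first, only, known or untested is meant among the compounds shown, and "the series" means these compounds.

Measured so far in an assay on isolated protein for inhibition of matrix metalloproteinase-9 (Homo sapiens), read by fluorescence, with stated times of 1 h and 15 min; on this read-out lower numbers stand for stronger inhibition and higher numbers for weaker inhibition:
compound 1, `O=C1[C@@H](NS(=O)(=O)c2ccc(Oc3ccc(Cl)cc3)cc2)CC=CCN1O`, gives 1120 nM;
compound 2, `O=C1[C@H](NS(=O)(=O)c2ccc(Oc3ccc(Cl)cc3)cc2)CC=CCN1O`, gives 0.58 nM;
compound 3, `O=C1[C@H](NS(=O)(=O)c2ccc(Oc3ccc(C(F)(F)F)cc3)cc2)CC=CCN1O`, gives 2 nM.

Compound 2 stands at the lowest number of the three, which on this read-out means the strongest inhibition. Its nearest neighbour is compound 3, reached by a 3.4-fold higher number from compound 2 to compound 3 (0.54 log units; beyond the scatter), where trifluoromethyl takes the place of chloro on an aromatic carbon. Its furthest neighbour is compound 1, reached by a 1900-fold lower number from compound 1 to compound 2 (3.29 log units; beyond the scatter), a large step that rests on configuration alone because of the fact that compounds 1 and 2 differ only in the configuration as drawn.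

Compound 4, `O=C1[C@H](N(CCN2CCCCC2)S(=O)(=O)c2ccc(Oc3ccc(Cl)cc3)cc2)CC=CCN1O`, differs from compound 2 by 2-(piperidin-1-yl)ethyl in place of hydrogen on a sulfonamide nitrogen. Neither measured step touches the sulfonamide nitrogen: the step from compound 1 to compound 2 changed only the drawn configuration, and the step from compound 2 to compound 3 changed only the group on the far aromatic ring. The measured steps therefore give no direct guide to this change, and the expectation is a change of at most modest size, a 3.4-fold higher number from compound 2 to compound 4 (0.54 log units; beyond the scatter). For compound 4 the estimated value in this assay is 2 nM, with a range from 0.3 nM to 15 nM.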

Compound 4, half-maximal inhibitory concentration: 0.21 nM
Compound 4: the middle estimate sits 9.5-fold (0.98 log units) above what was measured; the measured number lies below the stated range.
By their numbers in this assay, from the lowest: compound 4; then compound 2; then compound 3; then compound 1.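

The sulfonamide nitrogen carries a hydrogen in compounds 1, 2 and 3, so those compounds could not show whether that hydrogen is needed for strong inhibition. Compound 4 shows that, on this pair at least, it is not: in this assay, putting 2-(piperidin-1-yl)ethyl in its place gives a 2.8-fold lower number from compound 2 to compound 4 (0.44 log units; beyond the scatter), a modest step towards stronger inhibition. A substituent of this size on the sulfonamide nitrogen is therefore tolerated, and inhibition is kept rather than lost.

On these data alone, how a plain methyl, a longer chain ending in the same piperidine, or a chain ending in a carboxylic acid would read at this nitrogen stays open. Nothing shown here explains why this step goes the way it does.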